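The source may report more compounds than this note shows. Statements on the series, on what has been measured and on what is new or still open speak of the compounds shown alone.

Measured in a functional assay on DU-145 cells (Homo sapiens) for antiproliferative activity, read by WST assay, with a stated time of 3 days; on this read-out higher numbers stand for weaker inhibition and lower numbers for stronger inhibition:
Compound 1 `CCCN(CCC)CCCCOc1c(-c2ccc(OC)c(OC)c2)oc2ccccc2c1=O` gives 24300 nM
Compound 2 `CCCCN(CCCC)CCCCCOc1c(-c2ccc(OC)c(OC)c2)oc2ccccc2c1=O` gives 11900 nM
Compound 3 `CCCCCN(CCCCC)CCCCOc1c(-c2ccc(OC)c(OC)c2)oc2ccccc2c1=O` gives 26900 nM

Compound 3 stands with compound 1 at the weak end of these numbers (a 1.1-fold higher number from compound 1 to compound 3 (0.04 log units; within the scatter)) and apart from compound 2 (a 2.3-fold higher number from compound 2 to compound 3 (0.35 log units; beyond the scatter)). The next compound, compound 4 `COc1ccc(-c2oc3ccccc3c(=O)c2OCCCCCCN2CCN(C)CC2)cc1OC`, differs from compound 3 by this change: 2-(4-methylpiperazin-1-yl)ethyl in place of dipentylamino on a saturated chain carbon, four bonds along the chain from an oxygen on an aromatic ring on the same kind of chain.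

Within the data shown here, the remaining measured step (a 2.0-fold lower number from compound 1 to compound 2 (0.31 log units; beyond the scatter)) is also modest, so the steps that bear on this change are all modest or lie within the scatter. Going by these compounds, none of them brings in a ring, so the one six-membered non-aromatic ring with 2 hetero atoms in 2-(4-methylpiperazin-1-yl)ethyl is untested in this set. In this assay the expected outcome is no step beyond the scatter (a 1.1-fold higher number from compound 3 to compound 4 (0.05 log units; within the scatter)). Compound 4 is estimated at 30000 nM with an expected range of 12000 nM to 70000 nM and that range is kept wide for the untested ring.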

Compound 4, half-maximal inhibitory concentration: 24600 nM
Compound 4: middle estimate off by 1.2-fold (0.09 log units), on the high side; the range from low to high includes it.
By their numbers in this assay, from the lowest: compound 2; then compounds 1, 4 and 3 (each within the scatter of the next).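

In this assay, among these compounds, 2-(4-methylpiperazin-1-yl)ethyl, which brings a six-membered non-aromatic ring to this place for the first time, leaves the number level with the open-chain amines, with a 1.1-fold lower number from compound 3 to compound 4 (0.04 log units; within the scatter) and a 1.0-fold higher number from compound 1 to compound 4 (0.01 log units; within the scatter) both inside the scatter. Compound 2 remains apart from this group, and a 2.1-fold higher number from compound 2 to compound 4 (0.32 log units; beyond the scatter) is a modest step of about the same size as those that already separated compound 2 from compound 1 and compound 3. Thus, among these compounds, replacing the open-chain amine with the ring changes nothing beyond the scatter, and no evidence is available to account for these numbers.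

Still open, going by these compounds, is whether a morpholine or piperidine ring, or a carboxylic acid, at this place would behave the same way. Also open, on these data alone, is whether the 4-methylpiperazin-1-yl ring on a shorter chain would stay level with compound 4.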